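Ethyl on the Urea Nitrogen Across Two Benzyl Cores

The compounds below may be only part of what the source reports. "The series", "measured", "known", "first", "only" and "open" are said of these compounds alone.

Compound 1 `NC(=O)N1CCN(C(=S)SCc2cn(Cc3ccccc3F)nn2)CC1` gives 11300 nM in a functional assay on MGC-803 cells (Homo sapiens) for cytotoxicity, read by MTT assay, with a stated time of 72 h; on this read-out higher numbers stand for weaker inhibition and lower numbers for stronger inhibition.
Compound 2 `CCNC(=O)N1CCN(C(=S)SCc2cn(Cc3ccccc3F)nn2)CC1` gives 2830 nM in this assay.
Compound 3 `Cc1ccc(Cn2cc(CSC(=S)N3CCN(C(N)=O)CC3)nn2)cc1` gives 29900 nM in this assay.

All three share one core, and they differ at two places. The first place is the group carried on the ring nitrogen: compound 3 differs from compound 1 by 4-methylphenyl in place of 2-fluorophenyl on a saturated chain carbon bound to an aromatic nitrogen, and this change gave a 2.6-fold higher number from compound 1 to compound 3 (0.42 log units; beyond the scatter). The second place is the terminal urea nitrogen: compound 2 differs from compound 1 by ethyl in place of hydrogen on an amide-type nitrogen, and this change gave a 4.0-fold lower number from compound 1 to compound 2 (0.60 log units; beyond the scatter).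

Compound 4 `CCNC(=O)N1CCN(C(=S)SCc2cn(Cc3ccc(C)cc3)nn2)CC1` has not yet been measured. It differs from compound 3 by ethyl in place of hydrogen on an amide-type nitrogen. For the measured compounds named here, this is the same change as the one from compound 1 to compound 2, made at the same place, but on the core of compound 3 rather than that of compound 1. Going by the values given here, the only measured instance of this change is the single step from compound 1 to compound 2, so the expectation rests on one case.

For compound 4 a step of a 4.0-fold lower number from compound 3 to compound 4 (0.60 log units; beyond the scatter) is expected in this assay, because a 4.0-fold lower number from compound 1 to compound 2 (0.60 log units; beyond the scatter) was the size of the earlier step. Compound 4 is therefore estimated at 7500 nM, with a likely range from 3000 nM to 19000 nM.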

Compound 4, half-maximal inhibitory concentration: 19800 nM
Compound 4: the middle estimate sits 2.6-fold (0.42 log units) below what was measured; the measured number lies above the stated range.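

Ethyl in place of hydrogen on the amide-type nitrogen gave a 1.5-fold lower number from compound 3 to compound 4 (0.18 log units; within the scatter) in this assay, so on the core of compound 3 this change cannot be told apart from repeat-measurement noise, yet the gap to the earlier step is no larger than two such steps can show by scatter alone: the same change on two cores in this assay, a 4.0-fold lower number (0.60 log units; beyond the scatter) from compound 1 to compound 2 and a 1.5-fold lower number (0.18 log units; within the scatter) from compound 3 to compound 4, 2.6-fold (0.42 log units) apart, within the scatter of two such steps
Read the other way, 4-methylphenyl in place of 2-fluorophenyl on the saturated chain carbon gave a 7.0-fold higher number from compound 2 to compound 4 (0.84 log units; beyond the scatter), and this step also agrees with its earlier counterpart within that scatter: the same change on two cores in this assay, a 2.6-fold higher number (0.42 log units; beyond the scatter) from compound 1 to compound 3 and a 7.0-fold higher number (0.84 log units; beyond the scatter) from compound 2 to compound 4, 2.6-fold (0.42 log units) apart, within the scatter of two such steps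
Each comparison rests on just two steps, so the data show no measurable dependence on the core, but they do not prove that either change carries over unchanged, since the ethyl step stands beyond the scatter on one core and within it on the other.

As far as these compounds go, it remains open whether a longer chain on the amide-type nitrogen, such as propyl or butyl, would give a step clearly beyond the scatter on both cores. Also open, from the compounds shown here alone, is whether the same holds with other groups in place of 2-fluorophenyl and 4-methylphenyl, such as unsubstituted phenyl or 4-methoxyphenyl.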